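Compound 3 and the Limit Set by Compound 1

A few compounds are considered here, and "the series" means these few. Any claim that something is new, unique, unknown or untested is made for them only; others in the source may bear on it.

In an ADME assay on MCF-10A cells (Homo sapiens) for cytotoxicity, read by MTT assay, with a stated time of 72 h (on this read-out lower numbers stand for stronger inhibition and higher numbers for weaker inhibition), compound 1 `Cc1cc2occ(-c3nc(-c4ccccc4)c(-c4ccccc4)n3-c3ccc([N+](=O)[O-])cc3)c(=O)c2cc1Cl` gives > 100000 nM, which is a limit of the assay and not a number. Compound 2 `Cc1cc2occ(-c3nc(-c4ccccc4)c(-c4ccccc4)n3-c3ccccc3Cl)c(=O)c2cc1Cl` has no single number, and its result stands as "not determined" (no result reported). The next structure is compound 3 `Cc1cc2occ(-c3nc(-c4ccccc4)c(-c4ccccc4)n3-c3ccc(Br)cc3)c(=O)c2cc1Cl`. Here 4-bromophenyl takes the place of 2-chlorophenyl on an aromatic nitrogen (4-bromophenyl in place of 2-chlorophenyl on an aromatic nitrogen). Within the data shown here, with no measured step to go on, a shift beyond the usual scatter is not expected in this assay, and the only guide is compound 1 at its limit of > 100000 nM. For compound 3 the estimated value is 70000 nM, with an expected range from 20000 nM to 100000 nM.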

Compound 3, half-maximal inhibitory concentration: > 100000 nM
Compound 3: no number, only a limit (the forecaster's own chance of this, stated with the estimate: 65%); middle value at least 1.4-fold (0.15 log units) away from the limit.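

In this assay, among these compounds, compound 1 and compound 3 both stand at a limit and not at a number, so no step between them can be read. The compounds shown leave open whether any group on the aromatic nitrogen changes this read-out.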